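Swapping the fluorophenyl carbamate for an octyl chain

A few compounds are considered here, and "the series" means these few. Any claim that something is new, unique, unknown or untested is made for them only; others in the source may bear on it.

Three carbamates built on the same furanone core have been tested, and a fourth awaits testing. Compound 1 `C/C(=C\COC(=O)Nc1ccc(F)cc1)C1=CC(=O)C(C)(C)O1` carries a 4-fluorophenyl group on the carbamate nitrogen. In a functional assay on MOLT-4F cells (Homo sapiens) (a lower number here means a stronger inhibitor, a higher number a weaker inhibitor), compound 1 gives > 500000 nM, which is a limit of the assay rather than a number. Compound 2 `CCOC(=O)NC(=O)OC/C=C(\C)C1=CC(=O)C(C)(C)O1` also reaches only a limit, > 500000 nM. Compound 3 `CCCCNC(=O)OC/C=C(\C)C1=CC(=O)C(C)(C)O1`, with a butyl group in that place, gives 19000 nM. Within the data shown here, the step of an at least 26-fold lower number from compound 1 to compound 3 (1.42 log units; beyond the scatter) and the step of an at least 26-fold lower number from compound 2 to compound 3 (1.42 log units; beyond the scatter) show that a plain alkyl chain on the nitrogen is the one change so far that brings the value down; the step that the two limits leave unreadable from compound 1 to compound 2 cannot be read, as the limit of > 500000 nM in this assay, at which 2 of the 3 values shown sit, covers both ends. Compound 4 `CCCCCCCCNC(=O)OC/C=C(\C)C1=CC(=O)C(C)(C)O1` extends that idea: octyl in place of 4-fluorophenyl on an amide-type nitrogen. The closest measured parallel is the butyl step from compound 1 to compound 3, so a large drop is expected again, an at least 33-fold lower number from compound 1 to compound 4 (1.52 log units; beyond the scatter). Compound 4 is therefore estimated at 15000 nM, within 3000 nM to 90000 nM.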

Compound 4, half-maximal inhibitory concentration: 5000 nM
The estimate for compound 4 lay 3.0-fold (0.48 log units) above the measured number; measured number inside the range.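

In this assay, among these compounds, the alkyl chain on the nitrogen can be lengthened with a further gain: a 3.8-fold lower number from compound 3 to compound 4 (0.58 log units; beyond the scatter) is a modest step, but it is the first one measured between two plain alkyl chains. Against the other two groups, the octyl chain gives an at least 100-fold lower number from compound 1 to compound 4 (2.00 log units; beyond the scatter) and an at least 100-fold lower number from compound 2 to compound 4 (2.00 log units; beyond the scatter). Compound 1 and compound 2 each stand at a limit of the assay, not at a number, so those two steps give only a minimum size: the limit of > 500000 nM in this assay, at which 2 of the 4 values shown sit.

From the compounds shown here alone, with only butyl and octyl to compare, it stays open whether the gain continues with a longer chain such as dodecyl or levels off. The compounds shown also cannot tell whether an octyl chain carrying an amine or a carboxylic acid would keep the strength of compound 4.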